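The source may hold more compounds than are shown below. What is called first, only, known or untested is meant among the compounds shown, and "the series" means these compounds.

In an ADME assay on microsomes from liver (Homo sapiens) for metabolic stability, read by LC-MS, with a stated time of 30 min, tested at 0.5 uM (on this read-out higher numbers stand for a more stable compound and lower numbers for a less stable compound), compound 1 (`c1ccc(-c2nc(-c3csc(N=C4NCCCN4)n3)cs2)cc1`) gives 83% and compound 3 (`c1cncc(-c2nc(-c3csc(N=C4NCCCN4)n3)cs2)c1`) gives 78% within the scatter of each other, while compound 2 (`Oc1ccccc1-c1nc(-c2csc(N=C3NCCCN3)n2)cs1`) gives 30% and stands well under both. Compound 4 (`CS(=O)(=O)c1ccc(-c2nc(-c3csc(N=C4NCCCN4)n3)cs2)cc1`) differs from compound 1 in one place, methylsulfonyl in place of hydrogen on an aromatic carbon. Among the compounds with values here, two measured steps bear on it: hydroxy in place of hydrogen on an aromatic carbon gave a number 53 percentage points lower from compound 1 to compound 2 (beyond the scatter) as a large step, and pyridin-3-yl in place of phenyl gave a number 5 percentage points lower from compound 1 to compound 3 (within the scatter) within the scatter. Compound 4 carries no hydroxy, so a drop on the scale of that to compound 2 at 30% is not expected. The expected change in this assay stays within the scatter (a number 8 percentage points lower from compound 1 to compound 4 (within the scatter)). Compound 4 is estimated at 75% and expected to fall in the range (55% to 90%).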

Compound 4, percent of the compound remaining: 87%
The estimate for compound 4 lay 12 percentage points below the measured number, and the stated range covers the measured number.
By their numbers in this assay, from the lowest: compound 2; then compounds 3, 1 and 4 (each within the scatter of the next).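

In this assay, methylsulfonyl on an aromatic carbon of a six-membered aromatic ring of carbon only, para to a large group, gives a number 4 percentage points higher from compound 1 to compound 4 (within the scatter) and so adds 4 heavy atoms at this position without a step beyond the scatter. Substitution on this ring therefore does not by itself bring a large step such as a number 53 percentage points lower from compound 1 to compound 2 (beyond the scatter). The data at hand give no reason for this result. On these data alone, whether the large step follows hydroxy itself or its place on the ring stays open. So does whether an amine or a carboxylic acid at this position would leave the number within the scatter.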